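From methylamide to cyclopentylamide on a shared core

The source may hold more compounds than are shown below. What is called first, only, known or untested is meant among the compounds shown, and "the series" means these compounds.

Compound 1, `CCC1C(=O)N(C)c2cnc(Nc3ccc(S(=O)(=O)NC)cc3)nc2N1c1ccn(C)n1`, gives 71.6 nM in an assay for inhibition of serine/threonine-protein kinase PLK2 (Homo sapiens), read by FRET and Z'-LYTE, with a stated time of 1 h; a lower number here means a stronger inhibitor, a higher number a weaker inhibitor.
Compound 2, `CC[C@@H]1C(=O)N(C)c2cnc(Nc3ccc(S(=O)(=O)NCCCO)cc3)nc2N1C1CCCC1`, gives 8.16 nM in this assay.
Compound 3, `CC[C@@H]1C(=O)N(C)c2cnc(-n3ccc4cc(C(=O)NC)ccc43)nc2N1C1CCCC1`, gives 8.6 nM in this assay.

Among these three numbers, compound 3 stands second highest. Its nearest neighbour is compound 2, whose value lies within the scatter of that of compound 3, so no order between the two can be read from these data. Compound 1 lies furthest away, with a number beyond the scatter above that of compound 3.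

Compound 4, `CC[C@@H]1C(=O)N(C)c2cnc(-n3ccc4cc(C(=O)NC5CCCC5)ccc43)nc2N1C1CCCC1`, has not yet been measured in this assay. It differs from compound 3 in one place: cyclopentyl in place of methyl on an amide-type nitrogen. Among the measured compounds shown here, no pair of measured compounds carries this same change, so the present set holds no step that could show what size of shift it brings. The expectation for compound 4 therefore rests on compound 3 and on the nature of the change alone. The step from compound 3 to compound 4 in this assay is expected to be small, a 1.4-fold higher number from compound 3 to compound 4 (0.14 log units; within the scatter), with no move beyond the scatter in either direction. Compound 4 is thus estimated to give 12 nM in this assay, within a range from 4 nM to 40 nM.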

Compound 4, half-maximal inhibitory concentration: 7.06 nM
Beside the measured number, compound 4's estimate is 1.7-fold (0.23 log units) above it, within the range that was stated.
By their numbers in this assay, from the lowest: compounds 4, 2 and 3 (each within the scatter of the next); then compound 1.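

In this assay, among the compounds shown here, cyclopentyl in place of methyl on an amide-type nitrogen gives a 1.2-fold lower number from compound 3 to compound 4 (0.09 log units; within the scatter), and this is the only step in the present set that isolates a change at one place. The earlier compounds shown here could not show what happens at this nitrogen, whereas this step shows that the 5 heavy atoms and the five-membered ring of cyclopentyl, in place of the 1 heavy atom of methyl, bring no move beyond the scatter on this shared core. The numbers record only that outcome, and no accompanying measurement bears on the reason for it.

The compounds shown leave open whether an amine, a carboxylic acid or a longer chain on this same amide-type nitrogen would also stay within the scatter, since methyl and cyclopentyl are the only two groups seen there. They also leave open whether cyclopentyl in place of methyl would give a step of similar size on another core, as this single pair offers no second instance of the change.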